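A few compounds are considered here, and "the series" means these few. Any claim that something is new, unique, unknown or untested is made for them only; others in the source may bear on it.

Measured compounds in this series:
compound 1 `COc1ccc(-n2c(SC)nnc2-c2cc(OC)c(OC)c(OC)c2)cc1`: > 60000 nM
compound 2 `CCSc1nnc(-c2cc(OC)c(OC)c(OC)c2)n1-c1ccc(OC)cc1`: > 60000 nM
compound 3 `COc1ccc(-n2c(SCc3ccccc3)nnc2-c2cc(OC)c(OC)c(OC)c2)cc1`: > 60000 nM

In a functional assay on HT-29 cells (Homo sapiens) for inhibition, read by MTT assay, with a stated time of 48 h (a higher number here means a weaker inhibitor, a lower number a stronger inhibitor), compound 1 reaches only a limit of the assay, > 60000 nM. Compound 2 likewise gives only a limit, > 60000 nM. Compound 3 also stops at a limit, > 60000 nM. Compound 2 therefore stands at the limit, and the two other values shown stand there too; all three sit at the limit of > 60000 nM in this assay, at which 3 of the 3 values shown sit. Compound 4 `COc1ccc(-n2c(SCc3ccc(C)cc3)nnc2-c2cc(OC)c(OC)c(OC)c2)cc1` differs from compound 2 by 4-methylphenyl in place of methyl on a saturated chain carbon bound to a sulfur. The measured steps that bear on this change are a step that the two limits leave unreadable from compound 2 to compound 3, together with a step that the two limits leave unreadable from compound 1 to compound 2 and a step that the two limits leave unreadable from compound 1 to compound 3; none of them has a readable size, since every value involved is a limit. For the measured compounds named here, nothing among the measured compounds therefore points to a change in this assay that could be read. For compound 4 the expectation in this assay is another limit, estimated as 80000 nM with a range from 30000 nM to 300000 nM. For compound 4 the expected step is a step that the limit leaves unreadable from compound 2 to compound 4, not readable beyond the limit.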

Compound 4, half-maximal inhibitory concentration: > 60000 nM
Compound 4 ended at the assay's limit (the forecaster's own chance of this, stated with the estimate: 85%); the middle value lies beyond the limit too.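

Compound 4 gives no readable step from compound 1, compound 2 or compound 3, since all four results in this assay are limits: the limit of > 60000 nM in this assay, at which 4 of the 4 values shown sit.

The compounds shown leave open whether any group on the saturated chain carbon bound to a sulfur gives a readable value in this assay.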